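This account rests on a few compounds, and the source may have more. Where it says the series, first, only, none or still open, it means among the compounds named here.

Compound 1, `CCCCCCCCCCCCCCCCc1nc(N2CCC2)nc(OC2CCC2)c1O`, gives 100% in a functional assay on cells (Lymphocyte, Homo sapiens), read by a luciferase reporter and ATP content, with a stated time of 48 h, tested at 1 uM; a higher number here means a weaker effect of the compound at the concentration tested, a lower number a stronger effect.
Compound 2, `CCCCCCCCCCCCCCc1nc(OC2CCC2)nc(N2CCC2)c1O`, gives 109%.
Compound 3, `CCCCCCCCCCCCCCCCc1nc(OC2CCC2)nc(OC2CCC2)c1O`, gives 98%.

The one counted change among these, (azetidin-1-yl in place of cyclobutyloxy on an aromatic carbon), gives a number 2 percentage points higher from compound 3 to compound 1 (within the scatter). Compound 2 is the highest of the three numbers, within the scatter of compound 1 and beyond it against compound 3; how the cores of compound 2 and compound 3 differ is not broken down here.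

Compound 4, `CCCCCCCCCCCCCCc1nc(N2CCC2)nc(N2CCC2)c1O`, differs from compound 2 by azetidin-1-yl in place of cyclobutyloxy on an aromatic carbon. This is the same kind of change as from compound 3 to compound 1, though the place differs: in compound 3 it is meta to a cyclobutyloxy group, in compound 2 meta to an azetidin-1-yl group. Resting on a number 2 percentage points higher from compound 3 to compound 1 (within the scatter), the expected step is no change at the digits printed from compound 2 to compound 4 (within the scatter). Compound 4 is therefore estimated at 109%, between 96% and 122%.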

Compound 4, a percentage reported as activity, at one concentration (the size of the read-out at that concentration, not a potency): 86%
Estimate against measurement, compound 4: 23 percentage points above, and the stated range ends above it.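

In this assay, the replacement of cyclobutyloxy by azetidin-1-yl on an aromatic carbon does not carry over unchanged from one core to the other: the same change on two cores in this assay, a number 2 percentage points higher (within the scatter) from compound 3 to compound 1 and a number 23 percentage points lower (beyond the scatter) from compound 2 to compound 4, 25 percentage points apart, beyond the scatter of two such steps. On the core of compound 2, the change gives a number 23 percentage points lower from compound 2 to compound 4 (beyond the scatter), which here means a stronger effect at the concentration tested. With a single pair on each core, this does not show which difference between the cores accounts for the gap, or what the change would do on a further core.

The compounds shown leave open how an open-chain amine such as dimethylamino would behave in the same place. Also open, as far as these compounds go, is what a much shorter alkyl chain would do on the core of compound 4.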